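Swapping the aryl amide for a small oxygen ring

This account rests on a few compounds, and the source may have more. Where it says the series, first, only, none or still open, it means among the compounds named here.

Measured so far:
- Compound 1, `O=C(Nc1ccc2nc(NC(=O)C3CCCCC3)sc2c1)c1ccccc1Cl`: 0.025 ug/mL
- Compound 2, `N#Cc1ccc(C(=O)Nc2ccc3nc(NC(=O)C4CCCCC4)sc3c2)cc1`: 3.3 ug/mL
- Compound 3, `O=C(Nc1ccc2nc(NC(=O)C3CCCCC3)sc2c1)c1ccc(Cl)cc1Cl`: > 4 ug/mL

These three compounds share a core and differ only in the group attached to one carbonyl carbon. In a functional assay on WI-38 VA13 cells (Homo sapiens) for cytotoxicity (on this read-out higher numbers stand for an effect only at larger amounts of compound and lower numbers for an effect already at smaller amounts), compound 1 gives 0.025 ug/mL. Compound 2 gives 3.3 ug/mL in this assay. For compound 3 the assay reports only a limit, > 4 ug/mL, so its true number is not known, and it sits at the limit of > 4 ug/mL in this assay, at which 1 of the 3 values shown sits. Two measured steps show how strongly this position matters: a 130-fold higher number from compound 1 to compound 2 (2.12 log units; beyond the scatter) and an at least 160-fold higher number from compound 1 to compound 3 (2.20 log units; beyond the scatter). Between the two weaker compounds the picture is flat: an at least 1.2-fold higher number from compound 2 to compound 3 (0.08 log units; that floor lies within the scatter).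

Compound 4, `O=C(Nc1nc2ccc(NC(=O)C3CCCO3)cc2s1)C1CCCCC1`, is not yet measured. It differs from compound 3 in that (oxolan-2-yl in place of 2,4-dichlorophenyl on a carbonyl carbon). Among the measured compounds shown here, no measured step replaces an aromatic group with a non-aromatic ring at this position, so the earlier steps give only indirect guidance: they show that changes here can be large, but both large steps led away from compound 1, and compound 3 is already at the limit. The expectation is therefore a small or no step beyond the scatter, a step that the limit leaves unreadable from compound 3 to compound 4, with a fair chance that only a limit is reported again. The estimate for compound 4 in this assay is 5 ug/mL, expected to lie between 1 ug/mL and 25 ug/mL.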

Compound 4, half-maximal effective concentration: 1.3 ug/mL
Compound 4: middle estimate off by 3.8-fold (0.59 log units), on the high side, within the range that was stated.
By their numbers in this assay, from the lowest: compound 1; then compound 4; then compound 2. At a limit, above all of these: compound 3.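

The oxolan-2-yl group brings a non-aromatic ring with an oxygen to this carbonyl carbon, and it gives a 2.5-fold lower number from compound 2 to compound 4 (0.40 log units; beyond the scatter) and an at least 3.0-fold lower number from compound 3 to compound 4 (0.48 log units; beyond the scatter) in this assay, so an aromatic ring here is not needed for a number lower than those two aromatic compounds give. Compound 3 stands at a limit, so the second of these steps gives only a floor for the change: the limit of > 4 ug/mL in this assay, at which 1 of the 4 values shown sits. The 2-chlorophenyl group still stands well apart, with a 52-fold higher number from compound 1 to compound 4 (1.72 log units; beyond the scatter), so among these four compounds, having an aromatic ring or not does not sort the numbers: aromatic groups lie on both sides of oxolan-2-yl, with compound 1 on the low side and compound 2 and compound 3 on the high side.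

The compounds shown leave open whether the ring oxygen of compound 4 matters or whether the non-aromatic ring alone accounts for the change, which a cyclopentyl group at the same place would help to separate. On these data alone, it is also open how an open chain, such as methoxyethyl, or a ring carrying an amine would behave here in this assay.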